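Swapping the halogenated phenyl on the shared core

This account rests on a few compounds, and the source may have more. Where it says the series, first, only, none or still open, it means among the compounds named here.

Compound 1, `COc1cc2c(Oc3ccc(NC(=O)c4nn(-c5ccccc5OC(F)(F)F)c(=O)cc4C)cc3F)ccnc2cc1OCCCN1CCCCC1`, gives 40 nM in a functional assay on MKN-45 cells (Homo sapiens) for inhibition, read by MTT assay, with a stated time of 72 h; on this read-out lower numbers stand for stronger inhibition and higher numbers for weaker inhibition.
Compound 2, `COc1cc2c(Oc3ccc(NC(=O)c4nn(-c5cccc(F)c5)c(=O)cc4C)cc3F)ccnc2cc1OCCCN1CCCCC1`, gives 130 nM in this assay.
Compound 3, `COc1cc2c(Oc3ccc(NC(=O)c4nn(-c5cccc(F)c5)c(=O)cc4C)cc3F)ccnc2cc1OCCCN1CCN(C)CC1`, gives 120 nM in this assay.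

Compound 2 has the highest number of the three, with compound 3 close to it and compound 1 clearly lower. Compound 4, `COc1cc2c(Oc3ccc(NC(=O)c4nn(-c5ccc(Cl)cc5)c(=O)cc4C)cc3F)ccnc2cc1OCCCN1CCCCC1`, differs from compound 2 in one place: 4-chlorophenyl in place of 3-fluorophenyl on an aromatic nitrogen. For the measured compounds named here, only one measured step touches this phenyl group, a 3.3-fold higher number from compound 1 to compound 2 (0.51 log units; beyond the scatter), and it involved a different substituent, so it gives no direct guide for moving a halogen around the ring. The step of a 1.1-fold lower number from compound 2 to compound 3 (0.03 log units; within the scatter) concerns another part of the molecule. Going by the values given here, with no close precedent, a step of modest size at most is expected, direction uncertain. Compound 4 is therefore estimated at 90 nM, with a range of 35 nM to 230 nM, meaning an expected step of a 1.4-fold lower number from compound 2 to compound 4 (0.16 log units; within the scatter).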

Compound 4, half-maximal inhibitory concentration: 230 nM
Estimate against measurement, compound 4: 2.6-fold (0.41 log units) below, and the stated range covers the measured number.
By their numbers in this assay, from the lowest: compound 1; then compounds 3, 2 and 4 (each within the scatter of the next).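

The exchange of 3-fluorophenyl for 4-chlorophenyl on the aromatic nitrogen gives a 1.8-fold higher number from compound 2 to compound 4 (0.25 log units; within the scatter), so this change of halogen and ring position does not clearly separate the two compounds. Against the 2-(trifluoromethoxy)phenyl group, however, 4-chlorophenyl gives a 5.8-fold higher number from compound 1 to compound 4 (0.76 log units; beyond the scatter), a clear gap. No available evidence explains either step.

The change moved the halogen and replaced it at once, so the effects of the element and its position remain tangled. Open questions are how 3-chlorophenyl or 4-fluorophenyl would compare, and how a phenyl carrying an amine or a carboxylic acid would behave here.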